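Methyl Ester to Benzyl Amide on a Brominated Naphthyridine Core

A few compounds are considered here, and "the series" means these few. Any claim that something is new, unique, unknown or untested is made for them only; others in the source may bear on it.

Compound 1 `COc1cccc(CNC(=O)c2nc(Br)c3cccnc3c2N[C@H]2CC[C@H](N)CC2)c1` gives 7000 nM in a functional assay on HEY cells (Homo sapiens) for cytotoxicity, read by MTT assay, with a stated time of 72 h; a lower number here means a stronger inhibitor, a higher number a weaker inhibitor.
Compound 2 `COC(=O)c1nc(Br)c2cccnc2c1N[C@H]1CC[C@H](N)CC1` gives > 20000 nM in this assay, which is a limit of the assay and not a number.
Compound 3 `N[C@H]1CC[C@H](NC(=O)c2nc(Br)c3cccnc3c2NCc2ccc(F)cc2)CC1` gives 7100 nM in this assay.

For the measured compounds named here, compound 2, the methyl ester, sits at the limit of the assay the limit of > 20000 nM in this assay, at which 1 of the 3 values shown sits, and is the one compound here for which only a limit is known. Going by the values given here, the step from the benzyl amide to the ester, an at least 2.8-fold higher number from compound 1 to compound 2 (0.45 log units; beyond the scatter), is the single measured step, and it shows that replacing the amide by the ester removes measurable activity. Compound 4 `COc1ccc(CNC(=O)c2nc(Br)c3cccnc3c2N[C@H]2CC[C@H](N)CC2)cc1` differs from compound 2 in the reverse sense: (4-methoxybenzyl)amino in place of methoxy on a carbonyl carbon. Because that change mirrors the change of an at least 2.8-fold higher number from compound 1 to compound 2 (0.45 log units; beyond the scatter) but runs the other way, a lower number is expected for compound 4, by at least the size of the measured step, bringing it back towards the range of compound 1 and compound 3. The expected step is an at least 2.6-fold lower number from compound 2 to compound 4 (0.42 log units; beyond the scatter). The estimate for compound 4 in this assay is 7500 nM, with a range from 3000 nM to 20000 nM.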

Compound 4, half-maximal inhibitory concentration: 4000 nM
The estimate for compound 4 lay 1.9-fold (0.27 log units) above the measured number; low and high end bracket the measured number.
By their numbers in this assay, from the lowest: compounds 4, 1 and 3 (each within the scatter of the next). At a limit, above all of these: compound 2.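

In this assay, the ester-to-amide change holds for a second methoxybenzyl group, with an at least 5.0-fold lower number from compound 2 to compound 4 (0.69 log units; beyond the scatter), so the earlier gain on this carbonyl carbon was not confined to the 3-methoxybenzyl amide of compound 1. Moving the methoxy group on the benzyl ring gives a 1.8-fold lower number from compound 1 to compound 4 (0.24 log units; within the scatter), and this assay therefore does not tell the 3-methoxyphenyl and 4-methoxyphenyl amides apart. Compound 2 is still known only as a limit of the assay and not as a number: the limit of > 20000 nM in this assay, at which 1 of the 4 values shown sits.

As far as these compounds go, it remains open whether the methoxy group contributes at all, which a plain benzyl amide or a hydroxy group in its place would address. Also open, from the compounds shown here alone, is how a carboxylic acid on this carbonyl carbon, or a longer chain between the amide nitrogen and the aromatic ring, would compare.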